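The source may hold more compounds than are shown below. What is called first, only, known or untested is meant among the compounds shown, and "the series" means these compounds.

Of the compounds shown here, three with a shared core have been measured in a functional assay for inhibition, with Rattus norvegicus as the target, at pH 7.35; on this read-out lower numbers stand for stronger inhibition and higher numbers for weaker inhibition. Compound 1 `CCC(NC(=O)C(CC(C)C)NC(=O)OCc1ccccc1)C(=O)C(=O)OC`, with methoxy on a carbonyl carbon, gives 280000 nM. Compound 2 `CCC(NC(=O)C(CC(C)C)NC(=O)OCc1ccccc1)C(=O)C(=O)NCC(C)C`, with isobutylamino there, gives 28000 nM, and compound 3 `CCC(NC(=O)C(CC(C)C)NC(=O)OCc1ccccc1)C(=O)C(=O)NCC1CCCCC1`, with (cyclohexylmethyl)amino, gives 66000 nM, the second highest of the three numbers. Compound 4 `CCC(NC(=O)C(CC(C)C)NC(=O)OCc1ccccc1)C(=O)C(=O)NCc1ccccc1` differs from compound 3 by one change: phenyl in place of cyclohexyl on a saturated chain carbon bound to an amide-type nitrogen. Phenyl replaces cyclohexyl on a saturated chain carbon bound to an amide-type nitrogen. Among the measured compounds shown here, the closest precedent is the modest change at that place, a 2.4-fold higher number from compound 2 to compound 3 (0.37 log units; beyond the scatter). The larger steps, a 10-fold lower number from compound 1 to compound 2 (1.00 log units; beyond the scatter) and a 4.2-fold lower number from compound 1 to compound 3 (0.63 log units; beyond the scatter), concern the methoxy replacement. For the measured compounds named here, no measured step swaps a saturated ring for an aromatic one. No step beyond the scatter is therefore expected, the estimated step being a 1.5-fold lower number from compound 3 to compound 4 (0.17 log units; within the scatter). Compound 4 is estimated at 45000 nM, with an expected range of 15000 nM to 130000 nM.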

Compound 4, half-maximal inhibitory concentration: 50000 nM
Beside the measured number, compound 4's estimate is 1.1-fold (0.05 log units) below it, and the stated range covers the measured number.
By their numbers in this assay, from the lowest: compounds 2, 4 and 3 (each within the scatter of the next, the first and the last beyond it); then compound 1.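

Phenyl in place of cyclohexyl at this place stays within the scatter (a 1.3-fold lower number from compound 3 to compound 4 (0.12 log units; within the scatter)), so a saturated and an aromatic ring of the same size are not told apart here. Phenyl in place of isopropyl also stays within it (a 1.8-fold higher number from compound 2 to compound 4 (0.25 log units; within the scatter)), while replacing methoxy with benzylamino goes beyond it (a 5.6-fold lower number from compound 1 to compound 4 (0.75 log units; beyond the scatter)), as the other two amino groups do. No evidence is at hand that explains this behaviour.

On these data alone, whether phenethyl or a pyridyl ring in place of benzyl would move the number beyond the scatter remains open. So does the effect of an amine or a carboxylic acid on the phenyl ring.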